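Cytotoxicity Tolerance Across Chlorophenyl Amides of a Shared Core

The source may hold more compounds than are shown below. What is called first, only, known or untested is meant among the compounds shown, and "the series" means these compounds.

Compound 3 `CC(Sc1nnc(-c2ccncc2)s1)C(=O)Nc1c(Cl)cccc1Cl` carries a 2,6-dichlorophenyl on its amide nitrogen. In an ADME assay on BHK-21 cells (Mesocricetus auratus) for cytotoxicity, with a stated time of 3 days (a higher number here means that more compound is tolerated, a lower number that less compound is tolerated), compound 3 reaches only the assay limit of > 50000 nM. Compound 1 `CC(Sc1nnc(-c2ccncc2)s1)C(=O)Nc1ccc(Cl)cc1Cl` likewise stops at the assay limit, giving > 50000 nM in this assay. Compound 2 `CC(Sc1nnc(-c2ccncc2)s1)C(=O)NCc1ccc(Cl)cc1` shows "not determined" (no result reported) in this assay. The step that the two limits leave unreadable from compound 1 to compound 3 therefore cannot be read, since both of its ends rest on (the limit of > 50000 nM in this assay, at which 2 of the 3 values shown sit). Compound 4 `CC(Sc1nnc(-c2ccncc2)s1)C(=O)Nc1ccc(Cl)cc1` differs from compound 3 by 4-chlorophenyl in place of 2,6-dichlorophenyl on an amide-type nitrogen. Within the data shown here, no measured step offers a readable size for this change; the sole guide is the limit of > 50000 nM in this assay, at which 2 of the 3 values shown sit. Compound 4 is thus expected to sit at the same limit, with an estimated step that the limit leaves unreadable from compound 3 to compound 4. Compound 4 is estimated at 70000 nM, between 30000 nM and 150000 nM.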

Compound 4, half-maximal cytotoxic concentration: > 50000 nM
Compound 4: only a limit was reported; the forecaster's own chance of this, stated with the estimate: 85%; the middle value is on the limit's open side.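

Compound 4, like compound 1 and compound 3, rests on a limit of the assay, so no step among these three compounds can be read. In this assay the compounds shown leave open whether these chlorophenyl changes alter tolerance at all.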